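Swapping Chloro for Nitro in a Cytotoxicity Series

The compounds below may be only part of what the source reports. "The series", "measured", "known", "first", "only" and "open" are said of these compounds alone.

Compound 2 `O=C1/C(=C\c2ccccc2Cl)c2ccccc2N1c1c(Cl)cccc1Cl` was tested in a functional assay on HuTu80 cells (Homo sapiens) for cytotoxicity, read by MTT assay, with a stated time of 72 h (on this read-out lower numbers stand for an effect already at smaller amounts and higher numbers for an effect only at larger amounts of compound), where compound 2 gave only a limit, > 100 ug/mL. Compound 3 `COc1ccc(/C=C2\C(=O)N(c3c(Cl)cccc3Cl)c3ccccc32)cc1OC` also gave only a limit in this assay, < 1 ug/mL. Compound 1 `Cc1ccc2nc(Cl)c(/C=C3\C(=O)N(c4c(Cl)cccc4Cl)c4ccccc43)cc2c1` has no result in this assay, "not determined" (no result reported). Thus two of the three entries sit at limits, the limit of < 1 ug/mL in this assay, at which 1 of the 3 values shown sits, and (the limit of > 100 ug/mL in this assay, at which 1 of the 3 values shown sits), and compound 2 stands at the end where an effect appears only at larger amounts. Compound 4 `O=C1/C(=C\c2ccccc2[N+](=O)[O-])c2ccccc2N1c1c(Cl)cccc1Cl` differs from compound 2 in one place: nitro in place of chloro on an aromatic carbon. Among the compounds with values here, no step between measured compounds is available here, so a shift no larger than the usual scatter is expected, with a modest chance that the number falls toward smaller amounts. Compound 4 is estimated at 60 ug/mL, between 10 ug/mL and 150 ug/mL, which means an expected step of an at least 1.6-fold lower number from compound 2 to compound 4 (0.22 log units; that floor lies within the scatter).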

Compound 4, concentration for half-maximal effect: 10 ug/mL
Estimate against measurement, compound 4: 6.0-fold (0.78 log units) above, and the stated range covers the measured number.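

The position held by the chloro group in compound 2 is sensitive to what sits there: in this assay, nitro in its place gives an at least 10-fold lower number from compound 2 to compound 4 (1.00 log units; beyond the scatter). Within the data shown here, this is the first change in one place, and compound 4 gives a single number rather than a limit. Going by these compounds, the true size of the step stays unknown because the value of compound 2 is only a limit: the limit of > 100 ug/mL in this assay, at which 1 of the 4 values shown sits.

On these data alone, whether other groups on this aromatic carbon, such as an amine or a carboxylic acid, would lower the number as well remains open. So does whether nitro would have the same effect elsewhere on this ring.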